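A few compounds are considered here, and "the series" means these few. Any claim that something is new, unique, unknown or untested is made for them only; others in the source may bear on it.

Of the compounds shown here, three sharing one core have been measured in a functional assay (trachea) for inhibition, with Cavia porcellus as the target (a lower number here means a stronger inhibitor, a higher number a weaker inhibitor), so far. Compound 1 (`CC1(C)c2ccc([N+](=O)[O-])cc2[C@@H](N2CCCC2=O)[C@@H]1O`) gives 2800 nM as its half-maximal inhibitory concentration, compound 2 (`CC1(C)c2ccc(C#N)cc2[C@@H](N2CCCCC2=O)[C@@H]1O`) gives 270 nM on the same read-out, and compound 3 (`CC1(C)c2ccc([N+](=O)[O-])cc2[C@@H](n2ccccc2=O)[C@@H]1O`) gives 150 nM and sits within the scatter of compound 2. Within the data shown here, the one measured step, a 19-fold lower number from compound 1 to compound 3 (1.27 log units; beyond the scatter), replaces the group on the saturated ring carbon and leaves nitro in place, so it gives no size for the next change.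

Compound 4 (`CC1(C)c2ccc(C#N)cc2[C@@H](n2ccccc2=O)[C@@H]1O`) keeps the group of compound 3 on that carbon and differs by cyano in place of nitro on an aromatic carbon. Among the measured compounds shown here, no measured pair isolates this exchange. For the measured compounds named here, compound 2 carries cyano but also has a different group on the saturated ring carbon, so it shows only that a cyano compound can give a value close to that of compound 3. No step beyond the scatter is therefore expected in this assay here, and the expected step is small: a 1.1-fold higher number from compound 3 to compound 4 (0.05 log units; within the scatter) as a working figure. Compound 4 is estimated at 170 nM with an expected range from 60 nM to 450 nM on this read-out.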

Compound 4, half-maximal inhibitory concentration: 1940 nM
The estimate for compound 4 lay 11-fold (1.06 log units) below the measured number; measured number above the stated range.
By their numbers in this assay, from the lowest: compounds 3 and 2 (each within the scatter of the next); then compounds 4 and 1 (each within the scatter of the next).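

In this assay the exchange of nitro for cyano on the aromatic carbon is now isolated, and it is not neutral at this position: the step is a 13-fold higher number from compound 3 to compound 4 (1.11 log units; beyond the scatter) with the group of compound 3 held on the saturated ring carbon. With cyano held, the six-membered aromatic group in place of the six-membered non-aromatic one gives a 7.2-fold higher number from compound 2 to compound 4 (0.86 log units; beyond the scatter) and so does not carry a lower number with it, although the same aromatic group gave a 19-fold lower number from compound 1 to compound 3 (1.27 log units; beyond the scatter) against a five-membered non-aromatic group with nitro in place. No measurement on these groups accounts for either new step.

Still open, going by these compounds, is the size of the nitro-to-cyano step when the six-membered non-aromatic group sits on the saturated ring carbon, which would show whether the two places act independently. On these data alone, how an amine or a carboxylic acid on this aromatic carbon would compare with nitro and cyano also remains open.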